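Pyridyl sulfonamides on the piperidinylpiperidine core

A few compounds are considered here, and "the series" means these few. Any claim that something is new, unique, unknown or untested is made for them only; others in the source may bear on it.

Working notes on the series. Compound 1 `CC1CCN(C2CCN(S(=O)(=O)c3cccnc3Cl)CC2)CC1` has been measured in a functional assay on DLD-1 cells (Homo sapiens) for antiproliferative activity, read by CellTiter-Glo, with a stated time of 72 h (on this read-out lower numbers stand for stronger inhibition and higher numbers for weaker inhibition), and gives only a limit, > 5000 nM; on the numbers shown compound 1 therefore stands at the limit of > 5000 nM in this assay, at which 1 of the 2 values shown sits, and carries no number of its own. Compound 2 `CC1CCN(C2CCN(S(=O)(=O)c3cccc(-c4ccc(F)cc4)c3)CC2)CC1` in this assay gives 12 nM. Going by the values given here, the two differ in the whole aryl group on the sulfonyl sulfur, so no single-point step between them is recorded; the pair shows only that one value is a limit and the other a number.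

Compound 3 `CC1CCN(C2CCN(S(=O)(=O)c3cncc(Br)c3)CC2)CC1` is the next variant and is not yet measured. It differs from compound 1 in one place: 5-bromopyridin-3-yl in place of 2-chloropyridin-3-yl on a sulfonyl sulfur. The pyridine ring and the single halogen remain; the halogen changes and sits where the name of the entering group says.

Because compound 1 reports only a limit, the step from it is expected rather than derived. Compound 3 is expected to gain on compound 1 by an at least 3.3-fold lower number from compound 1 to compound 3 (0.52 log units; beyond the scatter), a step beyond the scatter. Compound 3 is estimated at 1500 nM, within 300 nM to 5000 nM.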

Compound 3, half-maximal inhibitory concentration: > 5000 nM
Compound 3: a limit, no number; the forecaster's own chance of this, stated with the estimate: 35%; middle value at least 3.3-fold (0.52 log units) from the limit.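

Compound 1 and compound 3 both report only a limit in this assay and no number, so no step can be read between them: the limit of > 5000 nM in this assay, at which 2 of the 3 values shown sit.

The compounds shown leave open how the 2-chloropyridin-3-yl and 5-bromopyridin-3-yl groups on the sulfonyl sulfur rank against each other.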